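The source may report more compounds than this note shows. Statements on the series, on what has been measured and on what is new or still open speak of the compounds shown alone.

Compound 2 `COc1ccccc1N1CCN(CCn2c(=O)[nH]c3cc(-c4cccc(Cl)c4)[nH]c3c2=O)CC1` gives 19.3 nM in an assay for binding affinity to Adrenergic receptor alpha-1 (Rattus norvegicus) (on this read-out higher numbers stand for weaker inhibition and lower numbers for stronger inhibition), the higher of the two numbers seen so far; compound 1 `COc1ccccc1N1CCN(CCn2c(=O)[nH]c3cc[nH]c3c2=O)CC1` gives 2.31 nM. Compound 3 `COc1ccccc1N1CCN(CCn2c(=O)[nH]c3cc(-c4ccc(Cl)cc4)[nH]c3c2=O)CC1` differs from compound 2 by 4-chlorophenyl in place of 3-chlorophenyl on an aromatic carbon. For the measured compounds named here, the only measured step, an 8.4-fold higher number from compound 1 to compound 2 (0.92 log units; beyond the scatter), added the whole chlorophenyl group; no step moves the chlorine within that ring, so it says little about the size of this change. A step within the scatter in this assay, in either direction, is therefore expected, giving a 1.0-fold higher number from compound 2 to compound 3 (0.02 log units; within the scatter). Compound 3 is estimated at 20 nM, with a likely range from 6 nM to 70 nM.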

Compound 3, inhibition constant: 7.68 nM
Compound 3: middle estimate off by 2.6-fold (0.42 log units), on the high side; low and high end bracket the measured number.
By their numbers in this assay, from the lowest: compound 1; then compound 3; then compound 2.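

In this assay, the place of the chlorine on the phenyl ring matters: moving it from the 3-chlorophenyl to the 4-chlorophenyl arrangement gives a 2.5-fold lower number from compound 2 to compound 3 (0.40 log units; beyond the scatter) on this carbon next to the ring nitrogen. Even so, hydrogen remains the better of the three, with a 3.3-fold higher number from compound 1 to compound 3 (0.52 log units; beyond the scatter) when 4-chlorophenyl replaces it. Nothing available explains why the chlorine's place changes the number. The compounds shown leave open how 2-chlorophenyl or plain phenyl would compare, and whether a small group such as an amine or a carboxylic acid on this carbon would match hydrogen.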